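A few compounds are considered here, and "the series" means these few. Any claim that something is new, unique, unknown or untested is made for them only; others in the source may bear on it.

Series notes. Three esters sharing one biaryl core have been run in an assay on COS-7 cells for inhibition of patatin-like phospholipase domain-containing protein 2 (Mus musculus), tested at 200 uM; on this read-out higher numbers stand for more inhibition at the one concentration tested (going by the name of the read-out) and lower numbers for less inhibition. Compound 1 `CCOC(=O)c1cccc(-c2ccc(OC)cc2)c1` gives 77%. Compound 2 `CCOC(=O)c1cccc(-c2ccc([N+](=O)[O-])cc2)c1` gives 63%, and compound 3 `CCOC(=O)c1cccc(-c2ccc(CN(C)C)cc2)c1` gives 67%.

The steps between them are small. With nitro in place of methoxy on an aromatic carbon the read-out moves a number 14 percentage points lower from compound 1 to compound 2 (beyond the scatter), beyond the scatter but modest. With (dimethylamino)methyl in place of methoxy on an aromatic carbon it moves a number 10 percentage points lower from compound 1 to compound 3 (within the scatter), within the scatter. With (dimethylamino)methyl in place of nitro on an aromatic carbon it moves a number 4 percentage points higher from compound 2 to compound 3 (within the scatter), again within the scatter. Compound 3 thus sits second of the three numbers, separated from both neighbours by less than the scatter.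

Compound 4 `CCOC(=O)c1cccc(-c2ccc(C(C)N(C)C)cc2)c1` differs from compound 3 by methyl in place of hydrogen on a saturated chain carbon bound to an amine nitrogen and an aromatic carbon, so the (dimethylamino)methyl group becomes 1-(dimethylamino)ethyl. No measured step touches this saturated chain carbon; the steps shown only exchange whole groups on the aromatic carbon, and even those exchanges stayed at or near the scatter in this assay. Nothing therefore argues for a step beyond the scatter in either direction. Compound 4 is expected to return 65%, between 50% and 78%, a change of a number 2 percentage points lower from compound 3 to compound 4 (within the scatter) that is expected to stay within the usual scatter.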

Compound 4, a percentage reported as inhibition, at one concentration (the size of the read-out at that concentration, not a potency): 50%
The estimate for compound 4 lay 15 percentage points above the measured number, and the stated range covers the measured number.
By their numbers in this assay, from the lowest: compound 4; then compounds 2, 3 and 1 (each within the scatter of the next, the first and the last beyond it).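

In this assay, the saturated chain carbon bound to an amine nitrogen and an aromatic carbon responds to a small change: methyl in place of hydrogen there gives a number 17 percentage points lower from compound 3 to compound 4 (beyond the scatter), while the earlier exchanges of (dimethylamino)methyl for methoxy or nitro on the aromatic carbon stayed within the scatter. The 1-(dimethylamino)ethyl group also separates from both other groups, with a number 13 percentage points lower from compound 2 to compound 4 (beyond the scatter) when it replaces nitro and a number 27 percentage points lower from compound 1 to compound 4 (beyond the scatter) when it replaces methoxy, so this side chain is not interchangeable with the groups tried on the aromatic carbon. Nothing at hand explains the step at this carbon.

Still open, as far as these compounds go, is whether ethyl or a second methyl on the same saturated chain carbon would continue the step in the same direction, and whether the two mirror-image forms of compound 4 read alike. Also open, from the compounds shown here alone, is whether a morpholine in place of the dimethylamino part, or a carboxylic acid in place of the ethyl ester, would shift the read-out.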